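A few compounds are considered here, and "the series" means these few. Any claim that something is new, unique, unknown or untested is made for them only; others in the source may bear on it.

Among the measured compounds shown here, in an ADME assay on HepG2 cells (Homo sapiens) for cytotoxicity, with a stated time of 72 h (a lower number here means that less compound is needed, a higher number that more compound is needed for the effect), compound 1 `Cc1cc(NC(=O)Nc2ccc(C(C)(C)C)cc2)c2ccccc2n1` gives 17000 nM, and this is the only exact number available so far. Compound 2 `COc1ccc(NC(=O)Nc2cc(C)nc3ccccc23)cc1OC` is reported as > 25000 nM, which is a limit of the test and not a number.

Compound 3 `Cc1cc(NC(=O)Nc2ccc(F)cc2)c2ccccc2n1` keeps the core of compound 1 and changes one group: fluoro in place of tert-butyl on an aromatic carbon. Fluoro takes the place of tert-butyl on an aromatic carbon, para to a large group. For the measured compounds named here, no two measured compounds differ in only one place, so the data give no direct guide to the size of this change.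

The expectation therefore rests on little. Compound 1, at 17000 nM, is the sole numerical anchor. The only other result, that of compound 2, is a limit. A small upward move in this assay is expected, a 1.6-fold higher number from compound 1 to compound 3 (0.20 log units; within the scatter), meaning slightly more compound would be needed for the effect, and this may not clear the usual scatter. For compound 3 the estimated value is 27000 nM, with an expected range from 12000 nM to 50000 nM, and a report of only a limit would be no surprise.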

Compound 3, half-maximal effective concentration: > 25000 nM
Compound 3: only a limit was reported; the forecaster's own chance of this, stated with the estimate: 60%; the middle value lies beyond the limit too.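

Fluoro in place of tert-butyl, para to a large group, gives the first comparison here between two compounds that differ in only one place. In this assay the change reads as an at least 1.4-fold higher number from compound 1 to compound 3 (0.16 log units; that floor lies within the scatter) and so shows that the much smaller fluoro, with one heavy atom where tert-butyl has four, does not bring the number down at this position. Only this lower bound on the step can be stated, and it cannot be called a real rise, because the result for compound 3 is a limit of the test and not a number: the limit of > 25000 nM in this assay, at which 2 of the 3 values shown sit.

The compounds shown leave open how far beyond that limit compound 3 truly lies, and so whether the full change would clear the usual scatter. They also leave open what an amine, a carboxylic acid or a longer chain at this same place on the aromatic ring would do in this assay and whether any such group would give an exact number on either side of compound 1 at all.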